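Anilide variation on a thiazolidinedione-bearing naphthyloxyacetamide series

A few compounds are considered here, and "the series" means these few. Any claim that something is new, unique, unknown or untested is made for them only; others in the source may bear on it.

Measured so far:
- compound 1, `COc1cccc(NC(=O)COc2ccc3cc(/C=C4/SC(=O)NC4=O)ccc3c2)c1`: 1600 nM
- compound 2, `O=C(COc1ccc2cc(/C=C3/SC(=O)NC3=O)ccc2c1)Nc1ccc(F)cc1F`: 3900 nM
- compound 3, `COc1ccc(NC(=O)COc2ccc3cc(/C=C4/SC(=O)NC4=O)ccc3c2)cc1`: 4700 nM

All three compounds share one core and differ only in the aryl group on the amide-type nitrogen. In an assay on isolated protein for inhibition of histone deacetylase 4 (Homo sapiens), with a stated time of 1 h (a lower number here means a stronger inhibitor, a higher number a weaker inhibitor), compound 1 gives 1600 nM, the lowest number of the three. Compound 2 stands second highest: the step of a 2.4-fold higher number from compound 1 to compound 2 (0.39 log units; beyond the scatter) is beyond the scatter, whereas the step of a 1.2-fold higher number from compound 2 to compound 3 (0.08 log units; within the scatter) is within it, so compound 2 and compound 3 cannot be told apart on these numbers. The step of a 2.9-fold higher number from compound 1 to compound 3 (0.47 log units; beyond the scatter) is likewise modest.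

Compound 4, `O=C(COc1ccc2cc(/C=C3/SC(=O)NC3=O)ccc2c1)Nc1ccc(Br)c(Br)c1`, has not yet been measured. Its difference from compound 2 is 3,4-dibromophenyl in place of 2,4-difluorophenyl on an amide-type nitrogen. The two measured steps that change the aryl group, a 2.4-fold higher number from compound 1 to compound 2 (0.39 log units; beyond the scatter) and a 1.2-fold higher number from compound 2 to compound 3 (0.08 log units; within the scatter), show that exchanging one substituted phenyl for another on this nitrogen has so far moved this assay only by modest amounts or not beyond the scatter. Going by the values given here, no measured compound carries a bromine or a 3,4-disubstitution pattern, so the direction cannot be read from the series.

For compound 4 the expectation is therefore a number close to that of compound 2, with the step of a 1.3-fold lower number from compound 2 to compound 4 (0.11 log units; within the scatter) estimated to lie within or just beyond the scatter in either direction. The estimated value for compound 4 is 3000 nM, with a range from 1200 nM to 8000 nM.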

Compound 4, half-maximal inhibitory concentration: 4900 nM
Estimate against measurement, compound 4: 1.6-fold (0.21 log units) below; low and high end bracket the measured number.
By their numbers in this assay, from the lowest: compound 1; then compounds 2, 3 and 4 (each within the scatter of the next).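

In this assay, the 3,4-dibromophenyl group on the amide-type nitrogen gives a number that cannot be separated from those of its two closest comparators, with a 1.3-fold higher number from compound 2 to compound 4 (0.10 log units; within the scatter) and a 1.0-fold higher number from compound 3 to compound 4 (0.02 log units; within the scatter) both printed as within the scatter. Compounds 2, 3 and 4 therefore form a single group on these numbers, even though their aryl groups carry fluorine, methoxy or bromine, and only the 3-methoxyphenyl group of compound 1 stands apart, as a 3.1-fold higher number from compound 1 to compound 4 (0.49 log units; beyond the scatter) shows with a step beyond the scatter but still modest. Nothing measured beyond these assay numbers bears on why this position responds so little to the change.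

From the compounds shown here alone, it remains open whether the small separation of compound 1 is specific to its 3-methoxyphenyl group or whether other groups at this position would match or extend it. The compounds shown carry only halogen or methoxy substituents on a phenyl ring, so a phenyl ring bearing an amine or a carboxylic acid, or a longer chain on this nitrogen, would test whether the position can move the number further.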